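A Larger Group on the Ring Nitrogen

The compounds below may be only part of what the source reports. "The series", "measured", "known", "first", "only" and "open" are said of these compounds alone.

In a functional assay on TMD8 cells (Homo sapiens) for cytotoxicity, read by CCK-8 assay, with a stated time of 72 h (a higher number here means a weaker inhibitor, a lower number a stronger inhibitor), compound 1 (`Cn1cc(NC(=O)c2cnc3ccc(N[C@@H]4CCCNC4)nn23)c(C(F)F)n1`) gives 1200 nM, compound 2 (`Cn1cc(NC(=O)c2cnc3ccc(N[C@@H]4CCCNC4)nn23)c(C(F)(F)F)n1`) gives 5900 nM and compound 3 (`CCn1cc(NC(=O)c2cnc3ccc(N[C@@H]4CCCNC4)nn23)c(C(F)(F)F)n1`) gives 6100 nM. Compound 3 therefore matches compound 2 within the scatter, and both are weaker than compound 1. Compound 4 (`O=C(Nc1cn(C2CCOCC2)nc1C(F)(F)F)c1cnc2ccc(N[C@@H]3CCCNC3)nn12`) has oxan-4-yl in place of ethyl on an aromatic nitrogen. The most relevant evidence is a change on that same nitrogen, methyl in place of hydrogen on the chain, which gave a 1.0-fold higher number from compound 2 to compound 3 (0.01 log units; within the scatter). The fluoro change, a 4.9-fold higher number from compound 1 to compound 2 (0.69 log units; beyond the scatter), lies elsewhere and bears less on this question. The new group is much larger than that small chain change, so the uncertainty is wide, but no shift beyond the scatter is expected. The expected step is a 1.2-fold lower number from compound 3 to compound 4 (0.09 log units; within the scatter). Compound 4 is estimated at 5000 nM, with an expected range of 2000 nM to 12000 nM.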

Compound 4, half-maximal inhibitory concentration: 11100 nM
For compound 4 the middle estimate is 2.2-fold (0.35 log units) below the measured one; measured number inside the range.
By their numbers in this assay, from the lowest: compound 1; then compounds 2, 3 and 4 (each within the scatter of the next).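

Placing oxan-4-yl on the aromatic nitrogen in place of ethyl gives a 1.8-fold higher number from compound 3 to compound 4 (0.26 log units; within the scatter) in this assay, and placing it there in place of methyl gives a 1.9-fold higher number from compound 2 to compound 4 (0.27 log units; within the scatter) in the same assay. For the compounds shown here, this position, until now seen only with methyl and ethyl, therefore also accepts a six-membered non-aromatic ring containing oxygen without a shift beyond the scatter. No measurement here offers an explanation for this result. Still open, on these data alone, is whether an amine-bearing group such as piperidin-4-yl or a carboxylic acid on this nitrogen would shift the number beyond the scatter. Also open, as far as these compounds go, is how oxan-4-yl would behave alongside the difluoromethyl group of compound 1.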